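This account rests on a few compounds, and the source may have more. Where it says the series, first, only, none or still open, it means among the compounds named here.

Measured compounds:
Compound 1, `CSc1nncc2c(C)nc(C)n12`: > 48000 nM in a functional assay for inhibition, with Homo sapiens as the target; a lower number here means a stronger inhibitor, a higher number a weaker inhibitor
Compound 2, `Cc1ncc2cnnc(O)n12`: > 48000 nM in this assay

In this assay compound 2 gives only a limit, > 48000 nM, and no number. Compound 1 likewise reaches only a limit, > 48000 nM. Compound 2 stands at the limit of > 48000 nM in this assay, at which 2 of the 2 values shown sit, so the two measured values show no difference between them, only that neither reaches a measurable inhibition. Compound 3, `CSc1nncc2cnc(C)n12`, has not yet been measured in this assay. The change from compound 2 is methylsulfanyl in place of hydroxy on an aromatic carbon. Among the measured compounds shown here, no step between measured compounds is known, and with both measured values sitting at the limit, no step beyond the scatter can be expected in this assay. Compound 3 is expected to remain at the limit as well, with an estimate of 60000 nM and a range from 20000 nM to 200000 nM. For compound 3 the expected step is a step that the limit leaves unreadable from compound 2 to compound 3, none beyond the scatter.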

Compound 3, half-maximal inhibitory concentration: > 48000 nM
Compound 3: only a limit was reported (the forecaster's own chance of this, stated with the estimate: 85%); the middle value is on the limit's open side.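

In this assay compound 3 gives > 48000 nM, which is only a limit. Among the compounds shown here, no step from compound 1 or compound 2 to compound 3 can therefore be read. The compounds shown leave open whether any change to the shared core would give measurable inhibition in this assay.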